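A few compounds are considered here, and "the series" means these few. Any claim that something is new, unique, unknown or untested is made for them only; others in the source may bear on it.

This account follows one structural change measured in a functional assay on DLD-1 cells (Homo sapiens) for antiproliferative activity, read by CellTiter-Glo, with a stated time of 72 h; on this read-out lower numbers stand for stronger inhibition and higher numbers for weaker inhibition. Compound 1 `Cc1ccc(C2CCN(S(=O)(=O)c3c(C)cc(C)cc3C)CC2)cc1` gives 2200 nM, which is the higher of the two numbers on hand. Compound 2 `CC1CCN(C2CCN(S(=O)(=O)c3ccccc3-c3ccccc3)CC2)CC1` gives 0.96 nM, a far lower number, and the gap between compound 1 and compound 2 lies well beyond the usual scatter. Compound 3 `C#CCOCCC1CCCCN1C1CCN(S(=O)(=O)c2ccccc2)CC1` reaches only a limit of the assay and no number, namely > 5000 nM. That limit is the one described in the limit of > 5000 nM in this assay, at which 1 of the 3 values shown sits.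

Compound 4 `Cc1cc(C)c(S(=O)(=O)N2CCC(N3CCCCC3)CC2)c(C)c1` has not yet been measured. It differs from compound 1 in one place: piperidin-1-yl in place of 4-methylphenyl on a saturated ring carbon. Within the data shown here, no measured pair of compounds makes this same change, so the size of the step can only be estimated from the neighbours. Compound 2 also carries a saturated nitrogen ring on that saturated ring carbon and gives 0.96 nM, whereas compound 3, which carries a more elaborate one, shows no number at all. The step of a 7.3-fold lower number from compound 1 to compound 4 (0.87 log units; beyond the scatter) is expected to be downward, toward stronger inhibition, and beyond the scatter. Compound 4 is therefore expected to give about 300 nM, most likely between 30 nM and 3000 nM.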

Compound 4, half-maximal inhibitory concentration: 2200 nM
Beside the measured number, compound 4's estimate is 7.3-fold (0.87 log units) below it, and the stated range covers the measured number.
By their numbers in this assay, from the lowest: compound 2; then compounds 1 and 4 (each within the scatter of the next). At a limit, above all of these: compound 3.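

With the rest of compound 1 held fixed, this position accepts a clear change of ring type: in this assay, replacing 4-methylphenyl with piperidin-1-yl on the saturated ring carbon gives no change at the digits printed from compound 1 to compound 4 (within the scatter). An aromatic carbon ring and a non-aromatic ring holding one nitrogen therefore cannot be told apart here, so in this setting, adding a saturated nitrogen ring at this carbon does not by itself lower the number. Nothing given here explains why the two groups match.

Among these compounds, whether the same swap would also leave the number unchanged with a different group on the sulfonyl remains open, as no measured pair tests it. Also untested on this carbon are other kinds of group, such as a morpholine ring, an open-chain amine or a carboxylic acid.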